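Replacing the carbamate of compound 3 with a difluorobenzamide

The source may hold more compounds than are shown below. What is called first, only, known or untested is meant among the compounds shown, and "the series" means these compounds.

In an ADME assay on HepG2 2.2.15 cells (Homo sapiens) for cytotoxicity (a lower number here means that less compound is tolerated, a higher number that more compound is tolerated), three compounds have been measured so far:

Compound 1, `CC(C)(C)OC(=O)Nc1ncc(C(Oc2ccc(Br)cc2)c2ccc(Cl)cc2)s1`, gives a limit of > 50000 nM.
Compound 2, `CC(C)(C)OC(=O)Nc1ncc(C(Oc2ccc(F)c(Cl)c2)c2ccc(Cl)cc2)s1`, gives a limit of > 50000 nM.
Compound 3, `CC(C)(C)OC(=O)Nc1ncc(C(Oc2ccc3cc(Br)ccc3c2)c2ccc(Cl)cc2)s1`, gives a limit of > 50000 nM.

Compound 3 therefore stands only at a limit of this assay, and its two companions stand at the same limit, so none of the three shows a number. The steps among them, a step that the two limits leave unreadable from compound 1 to compound 2, a step that the two limits leave unreadable from compound 1 to compound 3 and a step that the two limits leave unreadable from compound 2 to compound 3, cannot be read, because every value sits at the limit of > 50000 nM in this assay, at which 3 of the 3 values shown sit.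

Compound 4, `O=C(Nc1ncc(C(Oc2ccc3cc(Br)ccc3c2)c2ccc(Cl)cc2)s1)c1ccc(F)cc1F`, has not yet been measured. It differs from compound 3 by 2,4-difluorophenyl in place of tert-butoxy on a carbonyl carbon: a tert-butoxy group leaves and a 2,4-difluorophenyl ring enters on a carbonyl carbon whose other neighbour is an amide-type nitrogen.

Among the measured compounds shown here, no measured step bears on this change, since all three steps are unreadable. For the measured compounds named here, the only guide is that compound 3 and its companions tolerate the full tested range. Compound 4 is expected to fall near 60000 nM, within 20000 nM to 200000 nM, most likely again only as a limit. The expected step is a step that the limit leaves unreadable from compound 3 to compound 4.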

Compound 4, half-maximal cytotoxic concentration: "not toxic" (no number reported)
Compound 4: no number reported; no gap can be computed for the estimate.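

In this assay, among the compounds shown here, compound 4 is reported only as not toxic, without a number, and compound 3 gives no number either, so no step between compound 3 and compound 4 can be read: the limit of > 50000 nM in this assay, at which 3 of the 4 values shown sit.

The compounds shown leave open at what concentration, if any, compound 3 or compound 4 becomes toxic to these cells.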